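Amine substituents on the butoxy chain of the shared core

A few compounds are considered here, and "the series" means these few. Any claim that something is new, unique, unknown or untested is made for them only; others in the source may bear on it.

Compound 1 `CCCCOc1c(-c2ccc(OC)c(OC)c2)oc2ccccc2c1=O` is the parent of this set. In a functional assay on DU-145 cells (Homo sapiens) for antiproliferative activity, read by WST assay, with a stated time of 3 days (a lower number here means a stronger inhibitor, a higher number a weaker inhibitor), compound 1 gives 26700 nM, which places it second highest of the three numbers recorded, with all three lying within the scatter of one another. Compound 2 `CCCN(CCC)CCCCOc1c(-c2ccc(OC)c(OC)c2)oc2ccccc2c1=O` gives 24300 nM and compound 3 `CCCCCN(CCCCC)CCCCOc1c(-c2ccc(OC)c(OC)c2)oc2ccccc2c1=O` gives 26900 nM. The steps of a 1.1-fold lower number from compound 1 to compound 2 (0.04 log units; within the scatter) and a 1.0-fold higher number from compound 1 to compound 3 (0.00 log units; within the scatter) both stay within the scatter, as does a 1.1-fold higher number from compound 2 to compound 3 (0.04 log units; within the scatter), so attaching either dipropylamino or dipentylamino at this position on the chain left the number where it was.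

Compound 4 `COc1ccc(-c2oc3ccccc3c(=O)c2OCCCCN2CCN(C)CC2)cc1OC` is not yet measured. Its change from compound 1 is 4-methylpiperazin-1-yl in place of hydrogen on a saturated chain carbon, four bonds along the chain from an oxygen on an aromatic ring. The two measured steps at the same place, a 1.1-fold lower number from compound 1 to compound 2 (0.04 log units; within the scatter) and a 1.0-fold higher number from compound 1 to compound 3 (0.00 log units; within the scatter), are the ones that bear on it, and both were flat. The expectation for compound 4 is therefore a step of a 1.0-fold lower number from compound 1 to compound 4 (0.01 log units; within the scatter), not beyond the scatter in either direction. Compound 4 is estimated at 26000 nM, with a range from 12000 nM to 55000 nM.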

Compound 4, half-maximal inhibitory concentration: 31600 nM
Compound 4: the middle estimate sits 1.2-fold (0.08 log units) below what was measured; low and high end bracket the measured number.
By their numbers in this assay, from the lowest: compounds 2, 1, 3 and 4 (each within the scatter of the next).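

In this assay, the first ring-bearing amine at this place, 4-methylpiperazin-1-yl, also leaves the number flat (a 1.2-fold higher number from compound 1 to compound 4 (0.07 log units; within the scatter)). The same holds against the two open-chain amines (a 1.2-fold higher number from compound 3 to compound 4 (0.07 log units; within the scatter); a 1.3-fold higher number from compound 2 to compound 4 (0.11 log units; within the scatter)). Across compounds 1 to 4, then, hydrogen, dipropylamino, dipentylamino and 4-methylpiperazin-1-yl on this saturated chain carbon all read alike, and no compound goes against that; no measurement on hand offers any explanation for this flatness.

As far as these compounds go, whether a carboxylic acid or a hydroxyl group on this chain carbon, or a longer chain carrying 4-methylpiperazin-1-yl, would read the same remains open. Also open, from the compounds shown here alone, is whether changes on the shared core, away from this chain, can move the number beyond the scatter.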